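Branching the amide nitrogen substituent in the benzimidazole glycinamide series

A few compounds are considered here, and "the series" means these few. Any claim that something is new, unique, unknown or untested is made for them only; others in the source may bear on it.

Measured so far:
- compound 1 `CN1CCC(N2CCN(C(=O)CNC(=O)c3nc4ccccc4n3Cc3ccccc3)CC2)CC1`: 686 nM
- compound 2 `CCCN(CC(=O)N1CCN(C2CCN(C)CC2)CC1)C(=O)c1nc2ccccc2n1Cc1ccccc1`: 18 nM

In a functional assay on CHO cells for antagonist activity at B1 bradykinin receptor (Macaca fascicularis), read by FLIPR and calcium flux (a lower number here means a stronger inhibitor, a higher number a weaker inhibitor), compound 1 gives 686 nM and compound 2 gives 18 nM. For the measured compounds named here, compound 2 stands lowest of the two numbers; its nearest neighbour is compound 1, and the only measured step, a 38-fold lower number from compound 1 to compound 2 (1.58 log units; beyond the scatter), came from propyl in place of hydrogen on an amide-type nitrogen.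

Compound 3 `CC(C)N(CC(=O)N1CCN(C2CCN(C)CC2)CC1)C(=O)c1nc2ccccc2n1Cc1ccccc1` differs from compound 2 only by isopropyl in place of propyl on an amide-type nitrogen. Going by the values given here, the one measured step bears on this position but not on this change: it shows that filling the amide-type nitrogen matters greatly, whereas the step to compound 3 keeps the same three carbons and only rearranges them. Among the compounds with values here, no measured pair shows what branching does here. A step within the scatter in this assay is therefore expected, with some chance of a modest loss. For compound 3 the expected step is a 1.6-fold higher number from compound 2 to compound 3 (0.19 log units; within the scatter). Compound 3 is estimated at 28 nM, with a range from 8 nM to 100 nM.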

Compound 3, half-maximal inhibitory concentration: 465 nM
Compound 3: the middle estimate sits 17-fold (1.22 log units) below what was measured; the whole stated range lies below it.
By their numbers in this assay, from the lowest: compound 2; then compounds 3 and 1 (each within the scatter of the next).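

In this assay the identity of the chain on the amide-type nitrogen matters, not just its carbon count: with the same atoms joined differently, isopropyl in place of propyl gives a 26-fold higher number from compound 2 to compound 3 (1.41 log units; beyond the scatter) and so removes most of what propyl had gained. Filling the nitrogen is therefore not enough in itself, as hydrogen to isopropyl gives only a 1.5-fold lower number from compound 1 to compound 3 (0.17 log units; within the scatter) and leaves compound 3 not distinguishable from compound 1. Nothing available accounts for the difference between the two chains.

Open, going by these compounds, is how the value depends on the length of an unbranched chain, with ethyl and butyl as the nearest tests. Also open, on these data alone, is whether isobutyl, a chain branched further out, follows propyl or isopropyl.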